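The source may hold more compounds than are shown below. What is called first, only, known or untested is meant among the compounds shown, and "the series" means these compounds.

Measured so far in an ADME assay on NIH3T3 cells (Mus musculus) for antiproliferative activity, read by sulforhodamine B assay, with a stated time of 48 h; a higher number here means a weaker inhibitor, a lower number a stronger inhibitor:
compound 1, `C[C@H]1N=C2C[C@H]3C[C@H](C3(C)C)[C@@]2(C)OC1=O`, gives > 1800000 nM, which is a limit of the assay and not a number.
compound 2, `CC1(C)[C@@H]2CC3=N[C@@H](CCC(=O)O)C(=O)O[C@@]3(C)[C@H]1C2`, gives > 1200000 nM, again a limit.
compound 3, `CC1(C)[C@H]2CC3=N[C@H](CCC(=O)O)C(=O)O[C@]3(C)[C@@H]1C2`, gives > 1200000 nM, also a limit.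

Compound 3 therefore stands at a limit in this assay, as do both of its measured neighbours, so none of the three gives a number to compare. Compound 4, `CC(C)(C)OC(=O)CC[C@H]1N=C2C[C@H]3C[C@H](C3(C)C)[C@@]2(C)OC1=O`, differs from compound 3 by tert-butyl in place of hydrogen on an oxygen next to a carbonyl group; the same difference, cut one bond further out, reads carboxy to tert-butoxycarbonyl. Two measured steps lead to compound 3. The step that the two limits leave unreadable from compound 1 to compound 3 sits between two limits and cannot be read. The step that the two limits leave unreadable from compound 2 to compound 3 likewise cannot be read, the two compounds differing only in configuration as drawn (the fact that compounds 2 and 3 differ only in the configuration as drawn). Neither step touches the oxygen next to the carbonyl group, so nothing measured here tells what a tert-butyl there does. With every value at a limit, compound 4 is expected to remain at a limit as well, a step that the limit leaves unreadable from compound 3 to compound 4 that means no change beyond the scatter. Compound 4 is accordingly estimated at 1500000 nM, within 300000 nM to 3000000 nM.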

Compound 4, half-maximal inhibitory concentration: > 1200000 nM
Compound 4: a limit, no number; the forecaster's own chance of this, stated with the estimate: 85%; the middle value does not contradict the limit.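

In this assay compound 4 gives > 1200000 nM, a limit of the assay and not a number, so its steps from compound 1 and from compound 3 cannot be read. The compounds shown leave open whether tert-butyl in place of hydrogen, or any other difference among them, changes antiproliferative activity at all.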